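A methoxymethyl swap on compound 2

The source may hold more compounds than are shown below. What is called first, only, known or untested is meant among the compounds shown, and "the series" means these compounds.

In a functional assay on ZR-75-1 cells (Homo sapiens) for cytotoxicity, read by MTT assay, with a stated time of 72 h (on this read-out lower numbers stand for an effect already at smaller amounts and higher numbers for an effect only at larger amounts of compound), compound 2 (`CCc1cccc2c(OC)c(-c3occ(C)c3C(=S)OC)ccc12`) gives 5.8 ug/mL, within the usual scatter of compound 1 (`CCOC(=O)c1c(C)coc1-c1ccc2c(CC)cccc2c1OC`) at 3.9 ug/mL. Compound 3 (`CCOc1c(-c2occ(C)c2C(=O)OC)ccc2c(CC)cccc12`) gives 1.2 ug/mL, a number clearly lower than that of compound 2. Compound 4 (`CCc1cccc2c(OC)c(-c3occ(C)c3COC)ccc12`) carries methoxymethyl in place of the sulfur-bearing group of compound 2: a group of 3 heavy atoms (2 carbon, 1 oxygen; no ring) in place of a group of 4 heavy atoms (2 carbon, 1 oxygen, 1 sulfur; no ring), on an aromatic carbon. Within the data shown here, only one measured step changes this same place, a 1.5-fold higher number from compound 1 to compound 2 (0.17 log units; within the scatter), and it is small. Among the measured compounds shown here, no measured compound carries methoxymethyl, so this evidence is thin. No shift beyond the scatter is therefore expected in this assay, and the estimated step is a 1.2-fold higher number from compound 2 to compound 4 (0.08 log units; within the scatter). For compound 4 the expected value is 7 ug/mL, with an estimated range of 2.5 ug/mL to 18 ug/mL.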

Compound 4, concentration for half-maximal effect: 9.7 ug/mL
Compound 4: middle estimate off by 1.4-fold (0.14 log units), on the low side; measured number inside the range.
By their numbers in this assay, from the lowest: compound 3; then compounds 1, 2 and 4 (each within the scatter of the next, the first and the last beyond it).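

Putting methoxymethyl in place of the sulfur-bearing group gives a 1.7-fold higher number from compound 2 to compound 4 (0.22 log units; within the scatter), so this swap on the five-membered ring does not separate the two compounds. Among these compounds, putting methoxymethyl in place of ethoxycarbonyl gives a 2.5-fold higher number from compound 1 to compound 4 (0.40 log units; beyond the scatter), the first modest change at this place that clears the scatter. No measurement shown here accounts for either step.

On these data alone, it remains open how an amine, a carboxylic acid or a longer chain would read at this place. As far as these compounds go, it is also open whether methoxymethyl would give a similar step on the core of compound 3.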